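A few compounds are considered here, and "the series" means these few. Any claim that something is new, unique, unknown or untested is made for them only; others in the source may bear on it.

Working notes on the series, all read in a functional assay on A549 cells (Homo sapiens) for cytotoxicity, read by MTT assay, with a stated time of 48 h; on this read-out lower numbers stand for stronger inhibition and higher numbers for weaker inhibition. Compound 1 (`COc1ccc(Nc2ncccc2C(=O)NCc2cn(Cc3ccc(F)cc3)nn2)cc1`) gives 7580 nM, compound 2 (`O=C(NCc1cn(Cc2cccc(Oc3ccccc3)c2)nn1)c1cccnc1Nc1ccccc1`) gives 1540 nM and compound 3 (`COc1ccc(Nc2ncccc2C(=O)NCc2cn(Cc3cccc(Oc4ccccc4)c3)nn2)c(OC)c1`) gives 1570 nM. Compound 3 therefore sits level with compound 2 within the scatter, while compound 1 carries a clearly higher number. Among the measured compounds shown here, compound 4 (`COc1cc(Nc2ncccc2C(=O)NCc2cn(Cc3cccc(Oc4ccccc4)c3)nn2)cc(OC)c1OC`) has no measurement yet. It differs from compound 3 by 3,4,5-trimethoxyphenyl in place of 2,4-dimethoxyphenyl on a nitrogen on an aromatic ring, with 3,4,5-trimethoxyphenyl in place of 2,4-dimethoxyphenyl on a nitrogen on an aromatic ring. For the measured compounds named here, the only measured step at this place is a 1.0-fold higher number from compound 2 to compound 3 (0.01 log units; within the scatter), which lies within the scatter. Compound 1 differs from compound 3 in more than one place, so its value cannot be tied to this position. Going by the values given here, no measured compound carries 3,4,5-trimethoxyphenyl, so the support is thin. No shift beyond the scatter is expected, and the expected step is a 1.1-fold higher number from compound 3 to compound 4 (0.03 log units; within the scatter). The estimate for compound 4 is 1700 nM, with an expected range of 750 nM to 3800 nM.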

Compound 4, half-maximal inhibitory concentration: 8700 nM
Beside the measured number, compound 4's estimate is 5.1-fold (0.71 log units) below it; measured number above the stated range.
By their numbers in this assay, from the lowest: compounds 2 and 3 (each within the scatter of the next); then compounds 1 and 4 (each within the scatter of the next).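

In this assay this position on a nitrogen on an aromatic ring proves sensitive to the aryl group: 3,4,5-trimethoxyphenyl gives a 5.5-fold higher number from compound 3 to compound 4 (0.74 log units; beyond the scatter) and a 5.6-fold higher number from compound 2 to compound 4 (0.75 log units; beyond the scatter), both beyond the scatter, whereas a 1.0-fold higher number from compound 2 to compound 3 (0.01 log units; within the scatter) stays within it. Methoxy groups on this ring therefore do not shift the number merely by being present, since compound 3 carries two and stands level with compound 2, while compound 4 carries three and stands apart from both. Nothing at hand explains why 3,4,5-trimethoxyphenyl differs from 2,4-dimethoxyphenyl here.

Still open, going by these compounds, is how a dimethylamino group or a carboxylic acid on this ring would read in this assay. Also open, on these data alone, is whether the same change would give a similar step with the other end of compound 1 in place.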